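A few compounds are considered here, and "the series" means these few. Any claim that something is new, unique, unknown or untested is made for them only; others in the source may bear on it.

Compound 1 `O=C(CSc1nc(Nc2ccccc2)c2ccccc2n1)Nc1ccc(F)cc1` gives 34100 nM in a functional assay on MDA-MB-231 cells (Homo sapiens) for inhibition, read by MTT assay, with a stated time of 72 h; on this read-out higher numbers stand for weaker inhibition and lower numbers for stronger inhibition; compound 2 `O=C(CSc1nc(Nc2ccccc2)c2ccccc2n1)Nc1ccc(C(F)(F)F)cc1` gives 11100 nM; compound 3 `C=CC(=O)Nc1cccc(NC(=O)CSc2nc(Nc3ccccc3F)c3ccccc3n2)c1` gives 18700 nM.

Compound 3 sits second highest of the three numbers, yet its gaps to compound 2 and to compound 1 both lie within the scatter, so no order among them can be claimed. Compound 4 `C=CC(=O)Nc1cccc(NC(=O)CSc2nc(Nc3cccc(Br)c3)c3ccccc3n2)c1` differs from compound 3 only in 3-bromophenyl in place of 2-fluorophenyl on a nitrogen on an aromatic ring. Going by the values given here, the single measured step, a 3.1-fold lower number from compound 1 to compound 2 (0.49 log units; beyond the scatter), concerns a different ring and a different exchange, so it bears on this change only loosely. Compound 4 is therefore expected to give a number close to that of compound 3, with a step of a 1.4-fold lower number from compound 3 to compound 4 (0.16 log units; within the scatter) at most, and an estimated value of 13000 nM, ranging from 5000 nM to 35000 nM.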

Compound 4, half-maximal inhibitory concentration: 19400 nM
The estimate for compound 4 lay 1.5-fold (0.17 log units) below the measured number; the measured number falls inside the stated range.
By their numbers in this assay, from the lowest: compounds 2, 3, 4 and 1 (each within the scatter of the next, the first and the last beyond it).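

Going by these compounds alone, exchanging the 2-fluorophenyl for the 3-bromophenyl on this nitrogen gives a 1.0-fold higher number from compound 3 to compound 4 (0.02 log units; within the scatter) in this assay and is the first step read at this position. The two groups cannot be told apart on this read-out, even though both the halogen and the place it occupies on the phenyl differ. Nothing available explains this result. Still open, from the compounds shown here alone, is whether a phenyl carrying an amine or a carboxylic acid on this nitrogen would give a number apart from these two. Also open, going by these compounds, is whether trifluoromethyl in place of fluoro would give a step on this nitrogen's phenyl.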